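Adenosine A3 series: acylhydrazide variation on the shared core

A few compounds are considered here, and "the series" means these few. Any claim that something is new, unique, unknown or untested is made for them only; others in the source may bear on it.

Working notes on a small set of acylhydrazides built on one ribose-bearing core. Compound 3, `CCNC(=O)[C@H]1O[C@@H](n2cnc3c(NNC(=O)c4ccco4)nc(Cl)nc32)[C@H](O)[C@@H]1O`, is the reference point for the step under study. In an assay on CHO cells for displacement of a labelled ligand from adenosine receptor A3 (Homo sapiens) (a higher number here means a weaker inhibitor, a lower number a stronger inhibitor), compound 3 gives only a limit, > 5000 nM, not a number. The two other members of the set show the same picture. Compound 1, `CCNC(=O)[C@H]1O[C@@H](n2cnc3c(NNC(=O)c4ccc(Cl)cc4)ncnc32)[C@H](O)[C@@H]1O`, gives only a limit in this assay, > 5000 nM. Compound 2, `CCNC(=O)[C@H]1O[C@@H](n2cnc3c(NNC(=O)c4ccc(Br)o4)ncnc32)[C@H](O)[C@@H]1O`, likewise gives only a limit in this assay, > 5000 nM. For the measured compounds named here, the step from compound 1 to compound 2 is therefore a step that the two limits leave unreadable from compound 1 to compound 2, and no measured step in the set can be read as a number. Going by the values given here, the one piece of evidence is the limit of > 5000 nM in this assay, at which 3 of the 3 values shown sit.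

Compound 4, `CCNC(=O)[C@H]1O[C@@H](n2cnc3c(NNC(=O)c4ccc[nH]4)nc(Cl)nc32)[C@H](O)[C@@H]1O`, differs from compound 3 by 1H-pyrrol-2-yl in place of furan-2-yl on a carbonyl carbon. Among the compounds with values here, no measured step touches this change, and nothing in the set shows a number for any member, so no direction beyond the scatter can be expected from the measured steps alone. On that basis compound 4 is expected to sit at or near the limit as well, with an estimated step from compound 3 to compound 4 of a step that the limit leaves unreadable from compound 3 to compound 4. The estimate for compound 4 in this assay is 8000 nM, with a range from 2500 nM to 40000 nM.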

Compound 4, inhibition constant: > 5000 nM
Compound 4 ended at the assay's limit; the forecaster's own chance of this, stated with the estimate: 80%; the middle value does not contradict the limit.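

Compound 3 and compound 4 each give only a limit in this assay, so the change from furan-2-yl to 1H-pyrrol-2-yl yields no readable step. The compounds shown leave open whether any acylhydrazide on the shared core gives a number in this assay, and how these two groups compare there. The set stands as follows: the limit of > 5000 nM in this assay, at which 4 of the 4 values shown sit.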